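Swapping pyrazole for triazole beside a carboxylic acid

The compounds below may be only part of what the source reports. "The series", "measured", "known", "first", "only" and "open" are said of these compounds alone.

Compound 1 `O=C(O)c1ccn(Cc2cc(Br)ccc2OCc2ccccc2)n1` carries its acid on a 3-carboxy-1H-pyrazol-1-yl group attached to a saturated chain carbon bound to an aromatic carbon. In a functional assay on CHO-K1 cells for antagonist activity at prostaglandin E2 receptor EP1 subtype (Homo sapiens), read by FLIPR (a lower number here means a stronger inhibitor, a higher number a weaker inhibitor), compound 1 gives 55 nM. Compound 2 `O=C(O)c1cnn(Cc2cc(Br)ccc2OCc2ccccc2)c1` differs in one place: a 4-carboxy-1H-pyrazol-1-yl ring stands in place of the 3-carboxy-1H-pyrazol-1-yl ring. In this assay compound 2 gives < 2000 nM, which is a limit of the assay and not a number. Because of this, the step that the limit leaves unreadable from compound 1 to compound 2 cannot be read, as the line the limit of < 2000 nM in this assay, at which 1 of the 2 values shown sits, states. Compound 2 therefore stands only somewhere under that limit, without a fixed number of its own.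

Compound 3 `O=C(O)c1cn(Cc2cc(Br)ccc2OCc2ccccc2)nn1` has not yet been measured. It differs from compound 2 by 4-carboxy-1H-1,2,3-triazol-1-yl in place of 4-carboxy-1H-pyrazol-1-yl on a saturated chain carbon bound to an aromatic carbon. For the measured compounds named here, the acid keeps its place on the ring; only one ring carbon becomes a nitrogen. Going by the values given here, no measured step covers this change, so the expectation rests on compound 2 alone and is loose. The step that the limit leaves unreadable from compound 2 to compound 3 is expected to stay within the scatter. Compound 3 is estimated at 600 nM, with a range from 60 nM to 4000 nM.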

Compound 3, inhibition constant: < 2000 nM
Compound 3: only a limit was reported; the forecaster's own chance of this, stated with the estimate: 45%; the middle value does not contradict the limit.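

In this assay compound 3 gives < 2000 nM, which is a limit of the assay and not a number, so no step from compound 1 or compound 2 to compound 3 can be read: the limit of < 2000 nM in this assay, at which 2 of the 3 values shown sit.

Left open is whether compound 2 and compound 3 differ at all, and where either truly stands against compound 1.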